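Amide chain swap on a trimethoxyphenyl anilide

The compounds below may be only part of what the source reports. "The series", "measured", "known", "first", "only" and "open" are said of these compounds alone.

Measured compounds:
compound 1, `CCCCC(=O)N(Cc1ccc(OC)c(O)c1)c1cc(OC)c(OC)c(OC)c1` — 300 nM
compound 2, `COC(=O)c1cc(CNc2cc(OC)c(OC)c(OC)c2)ccc1OC` — 41100 nM

In a functional assay on KYSE-450 cells (Homo sapiens) for inhibition, read by MTT assay, with a stated time of 48 h (a lower number here means a stronger inhibitor, a higher number a weaker inhibitor), compound 1 gives the lower of the two numbers; compound 2, the only other one measured, gives 41100 nM in this assay, a gap well beyond the scatter. Compound 3, `C=C(C)C(=O)N(Cc1ccc(OC)c(O)c1)c1cc(OC)c(OC)c(OC)c1`, is not yet measured. It differs from compound 1 in one place: 1-methylethenyl in place of butyl on a carbonyl carbon. Within the data shown here, no measured pair shows this change, so the size of the step is unknown. Given the value 300 nM of compound 1, the expected step of a 1.3-fold higher number from compound 1 to compound 3 (0.12 log units; within the scatter) is small, likely within the scatter. Compound 3 is estimated at 400 nM, ranging 100 nM to 1500 nM.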

Compound 3, half-maximal inhibitory concentration: 200 nM
For compound 3 the middle estimate is 2.0-fold (0.30 log units) above the measured one; measured number inside the range.
By their numbers in this assay, from the lowest: compounds 3 and 1 (each within the scatter of the next); then compound 2.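

In this assay the swap of butyl for 1-methylethenyl on a carbonyl carbon gives a 1.5-fold lower number from compound 1 to compound 3 (0.18 log units; within the scatter) and so shows that this position accepts both groups without a change beyond the scatter. Among these compounds, compound 1 and compound 3 are the only pair here that differs in one place, so this is the only direct reading of this position. Nothing available explains why the two groups read alike. Still open, going by these compounds, is whether a longer chain, a phenyl ring or an amine on this carbonyl carbon would keep the number in the same range.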